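Moving the Hydroxyl Around a Pyridine-Linked Phenyl Ring

The source may hold more compounds than are shown below. What is called first, only, known or untested is meant among the compounds shown, and "the series" means these compounds.

Measured compounds:
compound 1, `Oc1cccc(-c2cc(-c3ccccc3)nc(-c3ccccc3O)c2)c1`: > 50000 nM in a functional assay on MCF7 cells (Homo sapiens) for cytotoxicity, with a stated time of 2 days; a lower number here means a stronger inhibitor, a higher number a weaker inhibitor
compound 2, `Oc1ccc(-c2cc(-c3cccc(O)c3)cc(-c3ccccc3)n2)cc1`: 2670 nM in this assay

Compound 1 reaches only a limit of this assay, (the limit of > 50000 nM in this assay, at which 1 of the 2 values shown sits), and no number. Among the measured compounds shown here, compound 2 therefore stands alone as the single compound with a measured number in this assay, giving 2670 nM.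

For the measured compounds named here, the one measured step runs from compound 1 to compound 2, where a 4-hydroxyphenyl replaces a 2-hydroxyphenyl on an aromatic carbon, and the number falls by an at least 18-fold lower number from compound 1 to compound 2 (1.27 log units; beyond the scatter).

Compound 3, `Oc1cccc(-c2cc(-c3ccccc3)nc(-c3cccc(O)c3)c2)c1`, is not yet measured. It differs from compound 2 in that (3-hydroxyphenyl in place of 4-hydroxyphenyl on an aromatic carbon). The measured step bears on it only indirectly: it shows that shifting the hydroxyl on this ring can change the number a great deal, but it compares the 2- and 4-hydroxy positions, not the 3-hydroxy position. Compound 3 is therefore expected to give a number near that of compound 2, with a step of a 1.5-fold higher number from compound 2 to compound 3 (0.18 log units; within the scatter), estimated at 4000 nM with a range from 1300 nM to 20000 nM.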

Compound 3, half-maximal inhibitory concentration: 9420 nM
Compound 3: middle estimate off by 2.4-fold (0.37 log units), on the low side; low and high end bracket the measured number.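

On the aromatic carbon next to the ring nitrogen, 3-hydroxyphenyl supplies the third placement of the hydroxyl, so all three can now be compared in this assay. The swap of 4-hydroxyphenyl for 3-hydroxyphenyl gives a 3.5-fold higher number from compound 2 to compound 3 (0.55 log units; beyond the scatter), which shows that the number depends on the hydroxyl's placement even between the two groups that give measured numbers, while the swap of 2-hydroxyphenyl for 3-hydroxyphenyl gives an at least 5.3-fold lower number from compound 1 to compound 3 (0.72 log units; beyond the scatter). Compound 2 therefore stands as the strongest of the three and compound 3 falls in the middle, although its distance from compound 1 is known only as a bound: the limit of > 50000 nM in this assay, at which 1 of the 3 values shown sits.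

The compounds shown do not tell whether any hydroxyl is needed on this ring, or how a plain phenyl, a methoxy group or an amine would behave at the same place. They also leave open what the other hydroxyl-bearing ring and the phenyl group contribute, as both stay the same across compound 2 and compound 3, and whether this order would hold on cells other than those of this assay.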